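This account rests on a few compounds, and the source may have more. Where it says the series, first, only, none or still open, it means among the compounds named here.

Three compounds share one core and differ only in the group on a sulfonyl sulfur. In an assay on isolated protein for activation of Nicotinamide phosphoribosyltransferase (Homo sapiens) (on this read-out higher numbers stand for an effect only at larger amounts of compound and lower numbers for an effect already at smaller amounts), compound 1 `CCN(C1CCCC1)S(=O)(=O)c1ccc(NC(=O)NCc2ccncc2)cc1` gives 60 nM, compound 2 `O=C(NCc1ccncc1)Nc1ccc(S(=O)(=O)N2CC3CCC(C2)O3)cc1` gives 279 nM, and compound 3 `NS(=O)(=O)c1ccc(NC(=O)NCc2ccncc2)cc1` gives 14300 nM, the highest of the three. The step to compound 4 `O=C(NCc1ccncc1)Nc1ccc(S(=O)(=O)N2CCc3ccccc3C2)cc1` is 1,2,3,4-tetrahydroisoquinolin-2-yl in place of amino on a sulfonyl sulfur. Going by the values given here, two measured steps bear on it: a 240-fold higher number from compound 1 to compound 3 (2.38 log units; beyond the scatter) and a 51-fold higher number from compound 2 to compound 3 (1.71 log units; beyond the scatter), both showing that the plain amino group sits far above any larger ring-bearing group on that sulfur. A large drop is therefore expected in this assay, estimated as a 120-fold lower number from compound 3 to compound 4 (2.08 log units; beyond the scatter). Compound 4 is expected to give about 120 nM, within a range from 30 nM to 600 nM.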

Compound 4, half-maximal effective concentration: 142 nM
Compound 4: the middle estimate sits 1.2-fold (0.07 log units) below what was measured; low and high end bracket the measured number.
By their numbers in this assay, from the lowest: compound 1; then compounds 4 and 2 (each within the scatter of the next); then compound 3.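

In this assay, going by these compounds alone, the 1,2,3,4-tetrahydroisoquinolin-2-yl group, the only group here with an aromatic ring of carbon only, also lies far from amino on the sulfonyl sulfur (a 100-fold lower number from compound 3 to compound 4 (2.00 log units; beyond the scatter)). So a large gain does not depend on the groups in compound 1 or compound 2. It lies within the scatter of one of these groups (a 2.0-fold lower number from compound 2 to compound 4 (0.29 log units; within the scatter)), while cyclopentyl(ethyl)amino keeps a modest lead (a 2.4-fold higher number from compound 1 to compound 4 (0.37 log units; beyond the scatter)).

No evidence here explains these differences. On these data alone, it remains open how a plain piperidine on the sulfur, or a fluoro or methoxy group on the aromatic ring, would compare.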